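From compound 3 to compound 4: an aryl exchange

The source may report more compounds than this note shows. Statements on the series, on what has been measured and on what is new or still open speak of the compounds shown alone.

In a functional assay on HepG2 cells (Homo sapiens) for cytotoxicity, read by MTT assay, with a stated time of 72 h (a lower number here means a stronger inhibitor, a higher number a weaker inhibitor), compound 1 `CNC(=O)c1cc(Oc2ccc(C(=O)/C=C/c3ccc(Cl)c(Cl)c3)cc2)ccn1` gives 11400 nM and compound 2 `CNC(=O)c1cc(Oc2ccc(C(=O)/C=C/c3ccc(F)cc3Cl)cc2)ccn1` gives 7320 nM. Compound 3 `CNC(=O)c1cc(Oc2ccc(C(=O)/C=C/c3ccc(OC)cc3)cc2)ccn1` has no single number: its result reads "not determined" (no result reported), so it offers no starting value. Compound 4 `CNC(=O)c1cc(Oc2ccc(C(=O)/C=C/c3ccc(Cl)cc3Cl)cc2)ccn1` follows from compound 3 by 2,4-dichlorophenyl in place of 4-methoxyphenyl on a double-bonded chain carbon bound to a double-bonded chain carbon. Going by the values given here, the only measured step bearing on this is a 1.6-fold lower number from compound 1 to compound 2 (0.19 log units; within the scatter), an exchange between two chlorine-bearing phenyl groups that stays within the scatter. No size or direction can therefore be expected for the step from compound 3, and compound 4 is expected to fall near compound 1 and compound 2. The estimate for compound 4 is 9000 nM, with an expected range of 4000 nM to 20000 nM.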

Compound 4, half-maximal inhibitory concentration: 11700 nM
Beside the measured number, compound 4's estimate is 1.3-fold (0.11 log units) below it; low and high end bracket the measured number.
By their numbers in this assay, from the lowest: compounds 2, 1 and 4 (each within the scatter of the next).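

In this assay chloro in place of fluoro on an aromatic carbon gives a 1.6-fold higher number from compound 2 to compound 4 (0.20 log units; within the scatter) and 2,4-dichlorophenyl in place of 3,4-dichlorophenyl gives a 1.0-fold higher number from compound 1 to compound 4 (0.01 log units; within the scatter) as a second exchange at this place. On a double-bonded chain carbon bound to a double-bonded chain carbon, the halogen-bearing phenyl groups of compound 1, compound 2 and compound 4 therefore cannot be told apart by this read-out. No supporting measurement bears on this result.

Open, on these data alone, is whether the 4-methoxyphenyl group of compound 3 stands with these groups, and whether an amine or a carboxylic acid on this phenyl group would move the number beyond the scatter.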